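Anilino for methylamino on the shared core: cytotoxicity check

The source may report more compounds than this note shows. Statements on the series, on what has been measured and on what is new or still open speak of the compounds shown alone.

Measured so far:
compound 1 `CCOc1ccc(NC(=O)c2c(N)n[nH]c2NC)cc1` — 21800 nM in a functional assay on Huh-7 cells (Homo sapiens) for cytotoxicity, read by resazurin assay, with a stated time of 48 h; a higher number here means a weaker inhibitor, a lower number a stronger inhibitor
compound 2 `CCN/C(SC)=C(/C#N)C(=O)Nc1ccc(OCC)cc1` — 16400 nM in this assay
compound 3 `CCOc1ccc(NC(=O)CC#N)cc1` — 21500 nM in this assay

The three numbers in this assay fall within the usual scatter of one another; compound 1 is not separated from compound 3 or from compound 2, so no ranking among them is supported. Within the data shown here, nothing here joins compounds that differ in a single place, so no measured step is available for reference.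

Compound 4 `CCOc1ccc(NC(=O)c2c(N)n[nH]c2Nc2ccccc2)cc1` is not yet measured. It differs from compound 1 by phenyl in place of methyl on a nitrogen on an aromatic ring, that is, methylamino to anilino. Among the measured compounds shown here, with no comparable step measured, the expectation for compound 4 rests only on the three numbers already seen, which sit close together. The step from compound 1 to compound 4 in this assay is expected to be small, a 1.2-fold lower number from compound 1 to compound 4 (0.08 log units; within the scatter), not beyond the scatter in either direction. Compound 4 is therefore estimated at 18000 nM in this assay, with a range from 6000 nM to 50000 nM.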

Compound 4, half-maximal inhibitory concentration: 4320 nM
Compound 4: the middle estimate sits 4.2-fold (0.62 log units) above what was measured; measured number outside the range, below it.
By their numbers in this assay, from the lowest: compound 4; then compounds 2, 3 and 1 (each within the scatter of the next).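

Among these compounds, this is the first single-place step measured, and it shows that the group on the nitrogen on an aromatic ring is not silent in this assay: phenyl in place of methyl gives a 5.0-fold lower number from compound 1 to compound 4 (0.70 log units; beyond the scatter). The change adds one six-membered aromatic ring of carbon only and no hydrogen-bond donors or acceptors, so in this pair the number moves with added carbon and a ring alone. No measured evidence bears on the reason for the step.

One pair gives no trend, and it leaves open whether the step follows the aromatic ring or the added carbon count. A cyclohexyl or benzyl group on the same nitrogen would bear on that question, while a chloro or methoxy group on the entering phenyl remains an open variation.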